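The source may hold more compounds than are shown below. What is called first, only, known or untested is meant among the compounds shown, and "the series" means these compounds.

Compound 1 `CCCCCCCCC(CCO)n1cnc2c(NC)ncnc21` and compound 2 `CCCCCCCCCC(CCO)n1cnc2c(NC)ncnc21` share one core, and the change between them is methyl in place of hydrogen on a saturated chain carbon, nine bonds along the chain from an aromatic nitrogen. In a functional assay on HCT-116 cells (Homo sapiens) for antiproliferative activity, read by MTT assay, with a stated time of 48 h (on this read-out lower numbers stand for stronger inhibition and higher numbers for weaker inhibition), compound 1 gives 3730 nM, while compound 2 gives 5410 nM; the step between them is a 1.5-fold higher number from compound 1 to compound 2 (0.16 log units; within the scatter). Compound 3 `CCCCCCCCCCC(CCO)n1cnc2c(Cl)ncnc21` carries a different core, and how that core differs from the core of compound 1 is not broken down here. In this assay compound 3 gives 4930 nM. Compound 4 `CCCCCCCCCCCC(CCO)n1cnc2c(Cl)ncnc21` has not yet been measured in this assay. It differs from compound 3 by methyl in place of hydrogen on a saturated chain carbon, ten or more bonds along the chain from an aromatic nitrogen, the same kind of change as that from compound 1 to compound 2, though at a different place along the chain. Because the earlier step was a 1.5-fold higher number from compound 1 to compound 2 (0.16 log units; within the scatter), a step of similar size is expected, a 1.3-fold higher number from compound 3 to compound 4 (0.12 log units; within the scatter), and compound 4 is estimated at 6500 nM.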

Compound 4, half-maximal inhibitory concentration: 7590 nM
Estimate against measurement, compound 4: 1.2-fold (0.07 log units) below, and the stated range covers the measured number.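

In this assay, methyl in place of hydrogen on the chain gives a 1.5-fold higher number from compound 3 to compound 4 (0.19 log units; within the scatter). Set beside the earlier step, the change reads alike on the two cores: the same change on two cores in this assay, a 1.5-fold higher number (0.16 log units; within the scatter) from compound 1 to compound 2 and a 1.5-fold higher number (0.19 log units; within the scatter) from compound 3 to compound 4, 1.1-fold (0.03 log units) apart, within the scatter of two such steps This shows only that the two steps agree on these two cores, at two different places along the chain; since each step lies within the scatter, it does not show that the added methyl shifts the number on either core, and two pairs establish no general rule for the series.

The compounds shown leave open how a much longer chain would read in this assay. They also leave open whether the agreement would hold on a core carrying an amine or a carboxylic acid.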